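The source may report more compounds than this note shows. Statements on the series, on what has been measured and on what is new or still open speak of the compounds shown alone.

Compound 3 `CC1CCN(c2c(S(=O)(=O)c3ccc(Cl)c(Cl)c3)cnc3ccc(Cl)cc23)CC1` stands second highest of the three compounds measured in an assay on isolated protein for displacement of a labelled ligand from metabotropic glutamate receptor 5 (Homo sapiens), with a stated time of 60 min, tested at 1 uM (on this read-out lower numbers stand for less inhibition and higher numbers for more inhibition at the one concentration tested (going by the name of the read-out)), where compound 3 gives 86%. Compound 1 `CC1CCN(c2c(S(=O)(=O)c3cccc(Cl)c3)cnc3ccc(Cl)cc23)CC1` gives 92% and compound 2 `CC1CCN(c2c(S(=O)(=O)c3ccccc3)cnc3ccc(Cl)cc23)CC1` gives 59%. Compound 4 `COc1ccc(S(=O)(=O)c2cnc3ccc(Cl)cc3c2N2CCC(C)CC2)cc1OC` differs from compound 3 in one place: 3,4-dimethoxyphenyl in place of 3,4-dichlorophenyl on a sulfonyl sulfur. Going by the values given here, no measured step swaps chloro for methoxy on this ring, but the steps that touch it were sizeable: a number 27 percentage points higher from compound 2 to compound 3 (beyond the scatter) and a number 33 percentage points lower from compound 1 to compound 2 (beyond the scatter), whereas a number 6 percentage points lower from compound 1 to compound 3 (within the scatter). Because a number 27 percentage points higher from compound 2 to compound 3 (beyond the scatter), removing both chlorines is expected to cost, with an estimated step of a number 41 percentage points lower from compound 3 to compound 4 (beyond the scatter), though the methoxy groups could soften or deepen that loss. Compound 4 is therefore estimated at 45%, within a range from 15% to 75%.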

Compound 4, a percentage reported as inhibition, at one concentration (the size of the read-out at that concentration, not a potency): 61%
For compound 4 the middle estimate is 16 percentage points below the measured one; the range from low to high includes it.
By their numbers in this assay, from the lowest: compounds 2 and 4 (each within the scatter of the next); then compounds 3 and 1 (each within the scatter of the next).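

In this assay the two methoxy groups on the ring attached to the sulfonyl sulfur do not match the chlorines, as 3,4-dimethoxyphenyl gives a clear loss against both 3,4-dichlorophenyl (a number 25 percentage points lower from compound 3 to compound 4 (beyond the scatter)) and 3-chlorophenyl (a number 31 percentage points lower from compound 1 to compound 4 (beyond the scatter)). Against plain phenyl, the same change cannot be told apart from scatter (a number 2 percentage points higher from compound 2 to compound 4 (within the scatter)), so among these compounds, substitution on this ring raises the number only when the substituent is chloro. No measured data here explain this difference. On these data alone, whether a single methoxy, a fluoro or a trifluoromethyl on this ring would behave like chloro remains open.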